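The compounds below may be only part of what the source reports. "The series", "measured", "known", "first", "only" and "open" are said of these compounds alone.

In a functional assay on KB cells (Homo sapiens) for inhibition (a higher number here means a weaker inhibitor, a lower number a stronger inhibitor), compound 1 `N/C(=N\O)c1cn([C@@H]2O[C@H](CO)[C@@H](O)[C@H]2O)c2nnnc(N)c12` gives 1500 nM, compound 3 `N=C(NN)c1cn([C@@H]2O[C@H](CO)[C@@H](O)[C@H]2O)c2nnnc(N)c12` gives 3000 nM and compound 2 `N#C/N=C(\N)c1cn([C@@H]2O[C@H](CO)[C@@H](O)[C@H]2O)c2nnnc(N)c12` gives 5000 nM. Two steps set the picture: a 2.0-fold higher number from compound 1 to compound 3 (0.30 log units; within the scatter), and a 3.3-fold higher number from compound 1 to compound 2 (0.52 log units; beyond the scatter). Compound 1 thus sits level with compound 3 and clearly under compound 2 on these numbers.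

Compound 4 `COC(=N)c1cn([C@@H]2O[C@H](CO)[C@@H](O)[C@H]2O)c2nnnc(N)c12` keeps the shared core and changes only the group on an aromatic carbon of the five-membered aromatic ring: a group of 4 heavy atoms (2 carbon, 1 nitrogen, 1 oxygen; no ring) in place of a group of 4 heavy atoms (1 carbon, 2 nitrogen, 1 oxygen; no ring), on an aromatic carbon. Going by the values given here, no measured compound carries the entering group, so the evidence is indirect. The measured swaps at this same place moved the number little. There is a 1.7-fold lower number from compound 2 to compound 3 (0.22 log units; within the scatter), and the largest step, already cited, is only modest. A small upward step is therefore expected, probably not beyond the scatter. The expected step is a 1.7-fold higher number from compound 1 to compound 4 (0.22 log units; within the scatter). For compound 4 the estimated value is 2500 nM, with an expected range of 800 nM to 8000 nM.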

Compound 4, half-maximal inhibitory concentration: 20000 nM
Beside the measured number, compound 4's estimate is 8.0-fold (0.90 log units) below it; measured number outside the range, above it.
By their numbers in this assay, from the lowest: compounds 1, 3 and 2 (each within the scatter of the next, the first and the last beyond it); then compound 4.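

Going by these compounds alone, this position is less forgiving than the earlier compounds suggested: their groups differed only modestly in this assay, yet a 13-fold higher number from compound 1 to compound 4 (1.12 log units; beyond the scatter) is a large loss. The loss does not depend on compound 1 as the reference, since a 6.7-fold higher number from compound 3 to compound 4 (0.82 log units; beyond the scatter) and a 4.0-fold higher number from compound 2 to compound 4 (0.60 log units; beyond the scatter) are also beyond the scatter, which sets the methoxy-bearing group of compound 4 apart from the other three groups. Nothing measured here explains this drop.

Going by these compounds, the entering group of compound 4 has one hydrogen-bond donor fewer than the group it replaces, and whether that difference matters remains open. Also open, on these data alone, is how a carboxylic acid, an amine or a longer chain such as ethoxy would fare at this aromatic carbon.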